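Swapping the Aryl Group on the Urea of Compound 1

The source may hold more compounds than are shown below. What is called first, only, known or untested is meant among the compounds shown, and "the series" means these compounds.

Compound 1 `O=C(NCCCOc1cccc(CN2CCCCC2)c1)Nc1cccc(C(F)(F)F)c1` — 813 nM
Compound 2 `CC(C)CNC(=O)NCCCOc1cccc(CN2CCCCC2)c1` — 170 nM

Going by the values given here, in an assay on isolated protein for inhibition of histamine H2 receptor (Cavia porcellus) (on this read-out higher numbers stand for weaker binding and lower numbers for tighter binding), compound 1 gives 813 nM, the higher of the two numbers measured so far. Among the compounds with values here, its nearest neighbour is compound 2, which gives 170 nM; the single step in hand is a 4.8-fold lower number from compound 1 to compound 2 (0.68 log units; beyond the scatter), where isobutyl replaces 3-(trifluoromethyl)phenyl on an amide-type nitrogen.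

Compound 3 `COc1ccc(NC(=O)NCCCOc2cccc(CN3CCCCC3)c2)c(OC)c1` is not yet measured. It differs from compound 1 by 2,4-dimethoxyphenyl in place of 3-(trifluoromethyl)phenyl on an amide-type nitrogen. Within the data shown here, no measured step compares one aryl group with another on that nitrogen; the only step available, a 4.8-fold lower number from compound 1 to compound 2 (0.68 log units; beyond the scatter), exchanges the aryl group for a chain, so it bears on the change only loosely. On that basis a change in this assay of at most modest size is expected, with the direction uncertain. Compound 3 is therefore estimated at 500 nM, with a range of 150 nM to 1600 nM, corresponding to the expected step of a 1.6-fold lower number from compound 1 to compound 3 (0.21 log units; within the scatter).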

Compound 3, dissociation constant: 2240 nM
Compound 3: the middle estimate sits 4.5-fold (0.65 log units) below what was measured; the measured number lies above the stated range.
By their numbers in this assay, from the lowest: compound 2; then compound 1; then compound 3.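

In this assay, the exchange of one aryl group for another on the amide-type nitrogen is itself a step beyond the scatter, with a 2.8-fold higher number from compound 1 to compound 3 (0.44 log units; beyond the scatter) for 2,4-dimethoxyphenyl in place of 3-(trifluoromethyl)phenyl, so the kind of aryl group matters here and not only the choice of aryl group or chain. Both aryl compounds now give higher numbers than isobutyl compound 2, and the gap widens to a large one with a 13-fold higher number from compound 2 to compound 3 (1.12 log units; beyond the scatter) between the chain and the 2,4-dimethoxyphenyl group. Nothing in the data at hand accounts for these differences.

The compounds shown leave open how an unsubstituted phenyl group or a phenyl group carrying a single methoxy would compare. They also leave open whether a cyclohexyl group or a longer alkyl chain would match or go beyond isobutyl compound 2.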